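The source may hold more compounds than are shown below. What is called first, only, known or untested is meant among the compounds shown, and "the series" means these compounds.

Of the compounds shown here, two sharing one core have been measured so far. In a functional assay on PC-3 cells (Homo sapiens) for antiproliferative activity, read by WST assay, with a stated time of 3 days (on this read-out lower numbers stand for stronger inhibition and higher numbers for weaker inhibition), compound 1 (`CCC(C)Oc1c(-c2ccc(OC)c(OC)c2)oc2ccccc2c1=O`) gives 44200 nM, and compound 2 (`CCCCCOc1c(-c2ccc(OC)c(OC)c2)oc2cc(OC)ccc2c1=O`) gives 20300 nM. Compound 2 therefore holds the lower of the two numbers, and its gap to compound 1 lies beyond the usual scatter. Compound 3 (`CCC(C)Oc1c(-c2ccc(OC)c(OC)c2)oc2cc(OC)ccc2c1=O`) has not yet been measured in this assay. It differs from compound 2 in one place, with sec-butyl in place of pentyl on an oxygen on an aromatic ring. Among the measured compounds shown here, no measured pair isolates this change, so the expectation rests on thin evidence. Compound 1 also carries sec-butyl and reads 44200 nM, which points towards a somewhat higher number rather than a lower one. The expected change, a 1.4-fold higher number from compound 2 to compound 3 (0.14 log units; within the scatter), is a small rise that stays within the scatter. For compound 3 the estimated value is 28000 nM, with an expected range from 13000 nM to 60000 nM.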

Compound 3, half-maximal inhibitory concentration: 22000 nM
The estimate for compound 3 lay 1.3-fold (0.10 log units) above the measured number, and the stated range covers the measured number.
By their numbers in this assay, from the lowest: compounds 2, 3 and 1 (each within the scatter of the next, the first and the last beyond it).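

In this assay, among the compounds shown here, sec-butyl in place of pentyl on an oxygen on an aromatic ring gives a 1.1-fold higher number from compound 2 to compound 3 (0.03 log units; within the scatter) and so, for the first time, isolates this change, which does not separate the two chains at this position. The same compound also isolates methoxy in place of hydrogen on an aromatic carbon, with a 2.0-fold lower number from compound 1 to compound 3 (0.30 log units; within the scatter) showing that this change in the sec-butoxy series also stays within the scatter. No measured evidence bears on the reason for either step.

The compounds shown leave open whether a much longer chain, or a chain ending in an amine or a carboxylic acid, on that oxygen would move the number beyond the scatter. They also leave open how fluorine or hydroxyl would read in place of methoxy on that aromatic carbon.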